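A few compounds are considered here, and "the series" means these few. Any claim that something is new, unique, unknown or untested is made for them only; others in the source may bear on it.

Three compounds share one core. Compound 1 `Cc1ccc(-c2cn(C/C=C3\OC(=O)C(OCc4ccccc4)=C3OCc3ccccc3)nn2)cc1` and compound 2 `COc1ccccc1-c1cn(C/C=C2\OC(=O)C(OCc3ccccc3)=C2OCc2ccccc2)nn1` carry a substituted 1H-1,2,3-triazol-1-yl group; in a functional assay on MCF7 cells (Homo sapiens) for antiproliferative activity, read by MTT assay, with a stated time of 72 h (a higher number here means a weaker inhibitor, a lower number a stronger inhibitor), compound 1 reaches only the limit of > 100000 nM. In this assay compound 2 likewise reaches only the limit of > 100000 nM. The step that the two limits leave unreadable from compound 1 to compound 2 therefore cannot be read. Among the measured compounds shown here, compound 3 `O=C1O[C@H]([C@@H](O)Cn2cc(C3CC3)nn2)C(OCc2ccccc2)=C1OCc1ccccc1` carries a 4-cyclopropyl-1H-1,2,3-triazol-1-yl group, and in this assay compound 3 gives 25900 nM, the only actual number among the three. The values of compound 1 and compound 2 are limits, (the limit of > 100000 nM in this assay, at which 2 of the 3 values shown sit). Compound 4 `O=C1O[C@H]([C@@H](O)Cn2cc(CCO)nn2)C(OCc2ccccc2)=C1OCc1ccccc1` differs from compound 3 in one place: 2-hydroxyethyl in place of cyclopropyl on an aromatic carbon. No measured step touches this kind of exchange; the single step shown, from compound 1 to compound 2, concerns a different group and is itself unreadable. So no direction can be drawn from the data, and a step no larger than the usual scatter is expected, a 1.2-fold higher number from compound 3 to compound 4 (0.06 log units; within the scatter). Compound 4 is therefore estimated to give about 30000 nM in this assay, within 10000 nM to 100000 nM.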

Compound 4, half-maximal inhibitory concentration: 63400 nM
Estimate against measurement, compound 4: 2.1-fold (0.32 log units) below; the range from low to high includes it.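

In this assay, among the compounds shown here, the exchange of cyclopropyl for 2-hydroxyethyl gives the first readable step in this set, a 2.4-fold higher number from compound 3 to compound 4 (0.39 log units; beyond the scatter), and a higher number here means a weaker inhibitor. The two groups have the same number of heavy atoms, so on this aromatic carbon of the triazole the kind of group matters even when that count stays the same, at least for this one pair. Compound 3 and compound 4 both give real numbers, while the other two compounds give only a limit of the assay: the limit of > 100000 nM in this assay, at which 2 of the 4 values shown sit.

This single pair cannot separate the opening of the ring from the arrival of the hydroxyl group, since both change together. A plain propyl chain would bear on that question, while a longer chain ending in an amine or a carboxylic acid remains an open case.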